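Swapping a methoxy for a hydroxy on a weak kinase-series urea

The source may hold more compounds than are shown below. What is called first, only, known or untested is meant among the compounds shown, and "the series" means these compounds.

Compound 3, with the structure `COc1cc(-c2nn(-c3cccc(NC(=O)Nc4cccc(C(F)(F)F)c4)c3)cc2-c2ccncc2)ccc1Cl`, is one of three close relatives measured in a functional assay on UO-31 cells (Homo sapiens) for inhibition, read by sulforhodamine B assay, with a stated time of 48 h; a lower number here means that less compound is tolerated, a higher number that more compound is tolerated. Its reading is a limit of the assay rather than a number: compound 3 gives > 50000 nM, which is the limit of > 50000 nM in this assay, at which 1 of the 3 values shown sits. The two measured companions carry a hydroxy where compound 3 carries a methoxy. Compound 1, with the structure `O=C(Nc1cccc(-n2cc(-c3ccncc3)c(-c3ccc(Cl)c(O)c3)n2)c1)Nc1ccc(Cl)c(Cl)c1`, also reaches only a limit, giving > 32500 nM in this assay, which is the limit of > 32500 nM in this assay, at which 1 of the 3 values shown sits. Within the data shown here, compound 2, with the structure `O=C(Nc1cccc(-n2cc(-c3ccncc3)c(-c3ccc(Cl)c(O)c3)n2)c1)Nc1cc(C(F)(F)F)cc(C(F)(F)F)c1`, is the only one to yield a number, giving 6600 nM in this assay.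

Compound 4, with the structure `O=C(Nc1cccc(-n2cc(-c3ccncc3)c(-c3ccc(Cl)c(O)c3)n2)c1)Nc1cccc(C(F)(F)F)c1`, has not yet been measured. It differs from compound 3 in one place: hydrogen in place of methyl on an oxygen on an aromatic ring. Taken one bond further out, this reads methoxy to hydroxy, or 4-chloro-3-methoxyphenyl to 4-chloro-3-hydroxyphenyl.

Among the measured compounds shown here, no step between measured compounds isolates this change, so the expectation rests on the hydroxy relatives, one of which sits at a limit and one of which gives a number. For compound 4 the step of an at least 1.6-fold lower number from compound 3 to compound 4 (0.22 log units; that floor lies within the scatter) is expected to be at most modest and cannot be placed firmly above the scatter. The estimate for compound 4 in this assay is 30000 nM, with a range from 8000 nM to 100000 nM.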

Compound 4, concentration lethal to 50% of the cells: > 32500 nM
Compound 4: only a limit was reported; the forecaster's own chance of this, stated with the estimate: 50%; middle value at least 1.0-fold (0.03 log units) away from the limit.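

In this assay compound 4 gives > 32500 nM, which is a limit of the assay, so placing a hydroxy where compound 3 has a methoxy does not produce a measurable number in this setting. The steps from compound 3 and from compound 1 to compound 4 cannot be read because each joins two limits, so neither a gain nor a loss can be stated for the methoxy to hydroxy change, and compound 4 shares its limit with compound 1: the limit of > 32500 nM in this assay, at which 2 of the 4 values shown sit.

Among these compounds, the one readable step is an at least 4.9-fold higher number from compound 2 to compound 4 (0.69 log units; beyond the scatter), with hydrogen in place of trifluoromethyl on an aromatic carbon, and it shows that within this pair of hydroxy compounds the hydroxy alone does not give the number seen for compound 2, since the extra trifluoromethyl is needed as well.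

Going by these compounds, how a methoxy would behave in the setting of compound 2, with its two trifluoromethyl groups, stays open. Also open, on these data alone, is whether an ethoxy or an amino group in place of the hydroxy on the 4-chloro-3-hydroxyphenyl would give a number in this assay.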